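Replacing the (morpholin-4-yl)carbonyl group of compound 3

This account rests on a few compounds, and the source may have more. Where it says the series, first, only, none or still open, it means among the compounds named here.

In an ADME assay for permeability, using PAMPA (a lower number here means that the compound crosses the layer more slowly, a higher number that the compound crosses the layer faster), compound 1 `COc1cc(N2CCN(C(=O)C3CCC(O)CC3)CC2)ccc1Nc1nc(NC2CCCCC2)c2nc[nH]c2n1` gives 81 10^-6 cm/s and compound 2 `COc1cc(N2CCN(Cc3ccccn3)CC2)ccc1Nc1nc(NC2CCCCC2)c2nc[nH]c2n1` gives 976 10^-6 cm/s. Among the compounds with values here, the only measured step between single-place analogues is large: a 12-fold higher number from compound 1 to compound 2 (1.08 log units; beyond the scatter). Compound 3 `COc1cc(N2CCC(C(=O)N3CCOCC3)CC2)ccc1Nc1nc(NC2CCCCC2)c2nc[nH]c2n1` gives 744 10^-6 cm/s, within the scatter of compound 2 and well clear of compound 1. Compound 4 `CCN(CC)CC1CCN(c2ccc(Nc3nc(NC4CCCCC4)c4nc[nH]c4n3)c(OC)c2)CC1` differs from compound 3 by (diethylamino)methyl in place of (morpholin-4-yl)carbonyl on a saturated ring carbon, on a saturated ring carbon. The measured step involves other groups, on an amine nitrogen in a ring, so it shows how far the number can move but gives no direction here. A moderate fall is nonetheless expected, an estimated 2.5-fold lower number from compound 3 to compound 4 (0.39 log units; beyond the scatter). For compound 4 the estimated value is 300 10^-6 cm/s, with an expected range from 80 10^-6 cm/s to 900 10^-6 cm/s.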

Compound 4, apparent permeability: 480 10^-6 cm/s
The estimate for compound 4 lay 1.6-fold (0.20 log units) below the measured number; the measured number falls inside the stated range.
By their numbers in this assay, from the lowest: compound 1; then compounds 4, 3 and 2 (each within the scatter of the next, the first and the last beyond it).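

In this assay, within the data shown here, putting (diethylamino)methyl in place of (morpholin-4-yl)carbonyl on this saturated ring carbon gives a 1.6-fold lower number from compound 3 to compound 4 (0.19 log units; within the scatter) and is the first step measured at this position. The two groups are not told apart by this read-out, although the ring and the carbonyl leave with the change. Among these compounds, a large step at an amine nitrogen in a ring therefore has no counterpart in this one exchange on a ring carbon.

From the compounds shown here alone, whether a carboxylic acid or a longer chain on this carbon would also stay within the scatter remains open. No measurement shown here bears on why these two groups give such similar numbers.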